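A Methyl on the Ring Amide Nitrogen, Tested Twice

This account rests on a few compounds, and the source may have more. Where it says the series, first, only, none or still open, it means among the compounds named here.

Compound 1 `CN1C/C(=C\c2ccc(Br)cc2)C(=O)[C@]2(C1)[C@@H](c1ccc(Br)cc1)CN(C)[C@@]21C(=O)Nc2ccccc21` and compound 2 `CN1C/C(=C\c2ccc(Br)cc2)C(=O)[C@]2(C1)[C@@H](c1ccc(Br)cc1)CN(C)[C@@]21C(=O)N(C)c2ccccc21` share one core and differ in a single spot: methyl in place of hydrogen on an amide-type nitrogen in a ring. In a functional assay on the whole organism (strain Wister albino) for inhibition, with Rattus norvegicus as the target, read by paw edema, with stated times of 1 h and 4 h, at a dose of 50 mg/kg by the intraperitoneal route (a lower number here means less inhibition, a higher number more inhibition at the dose given (going by the name of the read-out)), compound 1 gives 66.8%, and compound 2 gives 46.8%, so that a number 20 percentage points lower from compound 1 to compound 2 (beyond the scatter). Compound 3 `Cc1ccc(/C=C2\CN(C)C[C@@]3(C2=O)[C@@H](c2ccc(C)cc2)CN(C)[C@@]32C(=O)Nc3ccccc32)cc1` differs from compound 1 in more than one place; the difference between the two cores is not broken down here. In this assay compound 3 gives 50.7%, which sits within the scatter of compound 2, while the value of compound 1 lies above it by more than the scatter. Compound 4 `Cc1ccc(/C=C2\CN(C)C[C@@]3(C2=O)[C@@H](c2ccc(C)cc2)CN(C)[C@@]32C(=O)N(C)c3ccccc32)cc1` is compound 3 with methyl in place of hydrogen on an amide-type nitrogen in a ring, the same change, at the same kind of place, as that from compound 1 to compound 2. Within the data shown here, because the one measured instance gave a number 20 percentage points lower from compound 1 to compound 2 (beyond the scatter), the change is expected to lower the number again, though a single prior step is a thin base and the size is uncertain; the expected step is a number 15.7 percentage points lower from compound 3 to compound 4 (beyond the scatter) in this assay. Compound 4 is therefore estimated at 35%, within 20% to 50%.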

Compound 4, a percentage reported as inhibition, in the whole organism at one dose (the size of the read-out at that dose, not a potency): 68.8%
Estimate against measurement, compound 4: 33.8 percentage points below, outside the stated range (above it).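

In this assay, methyl in place of hydrogen on an amide-type nitrogen in a ring gave a number 18.1 percentage points higher from compound 3 to compound 4 (beyond the scatter). Set beside the earlier step, the same change did not keep its direction from one core to the other: the same change on two cores in this assay, a number 20 percentage points lower (beyond the scatter) from compound 1 to compound 2 and a number 18.1 percentage points higher (beyond the scatter) from compound 3 to compound 4, 38.1 percentage points apart, beyond the scatter of two such steps. This shows that, across these two pairs, the result of adding the methyl depends on the core that carries it, so a step measured on one core could not be carried over to the other; it does not show which feature of the cores is responsible, as compound 1 and compound 3 differ in more than one place, and two pairs set no rule for a third core.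

The compounds shown leave open how a longer chain such as ethyl, or a benzyl group, on the same nitrogen would read on either core. They also leave open whether the reversal would persist on a core carrying chloro or methoxy groups in place of the bromo or methyl groups.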